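This account rests on a few compounds, and the source may have more. Where it says the series, first, only, none or still open, it means among the compounds named here.

Measured so far in a functional assay on NCI-H460 cells (Homo sapiens) for cytotoxicity, read by MTT assay, with a stated time of 72 h; a lower number here means a stronger inhibitor, a higher number a weaker inhibitor:
compound 1, `COc1cc2c(Oc3ccc(NC(=O)c4cc(-c5ccccc5)ccn4)cc3F)ccnc2cc1OCCCN1CCCC1`: 130 nM
compound 2, `COc1cc2c(Oc3ccc(NC(=O)c4nccc(-c5ccc(F)cc5)n4)cc3F)ccnc2cc1OCCCN1CCN(C)CC1`: 63 nM
compound 3, `COc1cc2c(Oc3ccc(NC(=O)c4nccc(-c5ccccc5)n4)cc3F)ccnc2cc1OCCCN1CCCC1`: 1120 nM

Compound 3 gives the highest number of the three in this assay; compound 1 stands nearest to it and compound 2 furthest away, both gaps beyond the scatter. For the measured compounds named here, the one single-point step among the measured compounds is an 8.6-fold higher number from compound 1 to compound 3 (0.94 log units; beyond the scatter); it concerns the ring that carries the carbonyl, not the distal phenyl, and so bears only indirectly on the change in hand.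

Compound 4, `COc1cc2c(Oc3ccc(NC(=O)c4nccc(-c5ccc(F)cc5)n4)cc3F)ccnc2cc1OCCCN1CCCC1`, differs from compound 3 by fluoro in place of hydrogen on an aromatic carbon. Going by the values given here, no measured pair shows this change on its own. Compound 2 carries the same 4-fluorophenyl group and gives 63 nM in this assay, but it differs from compound 3 in two places, so that value cannot be credited to the fluoro alone. A modest step toward a lower number is therefore expected. Compound 4 is estimated at 450 nM (range 130 nM to 1500 nM). That estimate means a step of a 2.5-fold lower number from compound 3 to compound 4 (0.40 log units; beyond the scatter) is expected.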

Compound 4, half-maximal inhibitory concentration: 300 nM
Compound 4: middle estimate off by 1.5-fold (0.18 log units), on the high side; low and high end bracket the measured number.
By their numbers in this assay, from the lowest: compound 2; then compound 1; then compound 4; then compound 3.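

In this assay, the change from phenyl to 4-fluorophenyl can now be read on its own, with the pyrrolidin-1-yl chain end held constant: the step is a 3.7-fold lower number from compound 3 to compound 4 (0.57 log units; beyond the scatter). Compound 4 also isolates the chain end, with pyrrolidin-1-yl in place of 4-methylpiperazin-1-yl giving a 4.8-fold higher number from compound 2 to compound 4 (0.68 log units; beyond the scatter), so the low number of compound 2 at 63 nM cannot be credited to the fluoro alone, as both single changes give steps beyond the scatter. No measured evidence bears on the cause of either step.

Still open, from the compounds shown here alone, is whether the fluoro step carries over to the 4-methylpiperazin-1-yl chain end or to the 4-phenylpyridin-2-yl group of compound 1. Also open, going by these compounds, is whether chloro or methoxy in the same place on the phenyl would give a step of similar size.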